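The source may report more compounds than this note shows. Statements on the series, on what has been measured and on what is new or still open speak of the compounds shown alone.

For the measured compounds named here, in a functional assay on CH1 cells (Homo sapiens) for inhibition, read by sulforhodamine B assay, with a stated time of 96 h (a higher number here means a weaker inhibitor of growth, a lower number a stronger inhibitor of growth), compound 1 `CC[C@@H](Nc1nc(NCc2ccccn2)c2ncn(C(C)C)c2n1)C(C)O` gives 20000 nM and compound 2 `CC[C@H](Nc1nc(NCc2ccccn2)c2ncn(C(C)C)c2n1)C(C)O` gives 15500 nM, so compound 2 stands level with its only neighbour. Compound 3 `CC[C@H](Nc1nc(NCc2ccccn2)c2ncn(C(C)C)c2n1)C(C)(C)O` differs from compound 2 by methyl in place of hydrogen on a saturated chain carbon bound to an oxygen on a saturated carbon and two saturated chain carbons, which turns 1-hydroxyethyl into 1-hydroxy-1-methylethyl. Going by the values given here, the only measured step, a 1.3-fold lower number from compound 1 to compound 2 (0.11 log units; within the scatter), is a matter of the fact that one of compounds 1 and 2 is drawn with a defined configuration and the other without, at the place where they differ and adds no atoms, so it bears only weakly on this change. No step beyond the scatter is therefore expected in this assay, though the range stays wide. The expected step is a 1.1-fold lower number from compound 2 to compound 3 (0.04 log units; within the scatter). Compound 3 is estimated at 14000 nM, with a range of 6000 nM to 32000 nM.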

Compound 3, concentration for 50% growth inhibition: 26000 nM
Estimate against measurement, compound 3: 1.9-fold (0.27 log units) below; the measured number falls inside the stated range.
By their numbers in this assay, from the lowest: compounds 2, 1 and 3 (each within the scatter of the next).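

In this assay, methyl in place of hydrogen on this saturated chain carbon, which turns 1-hydroxyethyl into 1-hydroxy-1-methylethyl, gives a 1.7-fold higher number from compound 2 to compound 3 (0.22 log units; within the scatter), and the wider comparison gives a 1.3-fold higher number from compound 1 to compound 3 (0.11 log units; within the scatter). The position therefore takes this added methyl with no step beyond the scatter, so all three compounds remain level. Nothing given here bears on this methyl change. The compounds shown leave open how this position answers to a longer chain in place of methyl, or to an amine in place of the hydroxyl.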